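The compounds below may be only part of what the source reports. "The series", "measured", "known", "first", "only" and "open" are said of these compounds alone.

Measured so far:
- compound 1, `CCOC(=O)C1=C(C)NC(COC)=C(C(=O)OC)C1c1ccccc1[N+](=O)[O-]`: 1760 nM
- compound 2, `CCOC(=O)C1=C(C)NC(COC(C)=O)=C(C(=O)OCC)C1c1cccc([N+](=O)[O-])c1`: 10 nM
- compound 3, `C=C(C)CCOC(=O)C1=C(C)NC(C)=C(C(=O)OC)C1c1cccc([N+](=O)[O-])c1`: 23 nM

All three share one core and were tested in a functional assay on HEK293 cells for antagonist activity at Voltage-dependent L-type calcium channel subunit alpha-1C (Oryctolagus cuniculus), read by FLIPR; on this read-out lower numbers stand for stronger inhibition and higher numbers for weaker inhibition. Among the three numbers, compound 3 stands second highest: its nearest neighbour is compound 2, whose number is lower by a margin that exceeds the usual scatter, and the furthest is compound 1, whose much higher number marks it as the weakest of the three by a wide margin.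

The next compound, compound 4 with structure `COC(=O)C1=C(C)NC(C)=C(C(=O)OCCCl)C1c1cccc([N+](=O)[O-])c1`, has not been measured yet. Set against compound 3, the change is chloro in place of 1-methylethenyl on a saturated chain carbon, two bonds along the chain from an oxygen next to a carbonyl group, so the ester chain on that side of the core becomes shorter and ends in a halogen, while the rest of the molecule is unchanged.

Among the measured compounds shown here, no pair of already measured compounds differs in just this one place, so there is no direct precedent for the size of the step. Since the core and the nitro-bearing aromatic ring of compound 3 are kept, and since trimming an ester chain is a modest alteration, the expected step from compound 3 to compound 4 in this assay is a 1.3-fold lower number from compound 3 to compound 4 (0.11 log units; within the scatter), which is not expected to reach beyond the scatter in either direction. Compound 4 is therefore estimated at 18 nM, with a plausible range from 6 nM to 55 nM.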

Compound 4, half-maximal inhibitory concentration: 26 nM
For compound 4 the middle estimate is 1.4-fold (0.16 log units) below the measured one; the range from low to high includes it.
By their numbers in this assay, from the lowest: compound 2; then compounds 3 and 4 (each within the scatter of the next); then compound 1.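

In this assay, putting chloro in place of 1-methylethenyl on a saturated chain carbon, two bonds along the chain from an oxygen next to a carbonyl group, gives a 1.1-fold higher number from compound 3 to compound 4 (0.05 log units; within the scatter). This is the first pair shown that differs in one place only, and so the first direct reading of this position: the 3-methylbut-3-en-1-yl chain and the 2-chloroethyl chain read alike here, even though the exchange removes three carbons and a double bond and brings in one chlorine. No accompanying data bear on why the two chains give such similar numbers.

As far as these compounds go, only these two chain ends can be compared, so it remains open whether a longer chain, or a chain ending in an amine or a carboxylic acid, would also leave the number within the scatter. One pair also cannot show whether the same exchange would read alike with different groups elsewhere on the shared core.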